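The source may hold more compounds than are shown below. What is called first, only, known or untested is meant among the compounds shown, and "the series" means these compounds.

Measured compounds:
Compound 1 `CN(C)c1ccc2nc(-c3cccc4ccccc34)[nH]c(=O)c2c1`: 460 nM
Compound 2 `COc1cccc(-c2nc3ccc(C)cc3c(=O)[nH]2)c1`: 32000 nM
Compound 3 `Cc1ccc2c(=O)[nH]c(-c3cccc(OC(F)(F)F)c3)nc2c1`: > 50000 nM (a limit, not a number)

In a functional assay on HCT-15 cells (Homo sapiens) for cytotoxicity, read by MTT assay, with a stated time of 2 days (on this read-out lower numbers stand for stronger inhibition and higher numbers for weaker inhibition), compound 1 gives 460 nM, the lowest of the two actual numbers. The nearest number belongs to compound 2, at 32000 nM, which is far higher and well beyond the scatter. Compound 3 has only a limit, > 50000 nM.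

The next compound, compound 4 `CCN(CC)c1ccc2nc(-c3cccc4ccccc34)[nH]c(=O)c2c1`, keeps the core of compound 1 and changes one group, with diethylamino in place of dimethylamino on an aromatic carbon. For the measured compounds named here, no measured pair of compounds shows this change, so the expectation starts from compound 1 at 460 nM. In this assay, the estimated 1.5-fold higher number from compound 1 to compound 4 (0.18 log units; within the scatter) is expected to be small and towards a somewhat higher number, and it may not exceed the scatter. For compound 4, the estimated value is 700 nM, with an expected range from 200 nM to 3000 nM.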

Compound 4, half-maximal inhibitory concentration: 3210 nM
The estimate for compound 4 lay 4.6-fold (0.66 log units) below the measured number, and the stated range ends below it.
By their numbers in this assay, from the lowest: compound 1; then compound 4; then compound 2. At a limit, above all of these: compound 3.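

In this assay, the change from dimethylamino to diethylamino gives a clear result: a 7.0-fold higher number from compound 1 to compound 4 (0.84 log units; beyond the scatter). Swapping these groups adds two carbons, while the hydrogen-bond donor and acceptor counts and the net charge stay the same, so this aromatic carbon of the core is sensitive to a change confined to the carbon part of the amine. For the compounds shown here, the earlier compounds could not show this, as no measured pair differed in one place, and this single step is the first reading of how the number responds at this position.

Going by these compounds, it remains open whether a primary amine, methylamino, or a ring amine such as pyrrolidine or morpholine would give a lower or a higher number here. The reason for the step also stays open, as nothing shown bears on it.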